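The compounds below may be only part of what the source reports. "The series", "measured", "known", "first", "only" and "open" are said of these compounds alone.

Measured compounds:
- compound 1, `CC1CC(OCCCCCCN2C[C@H](O)[C@@H](O)[C@H](O)[C@H]2CO)CC(C)(C)C1` — an ADME assay on MDBK cells (Bos taurus) for cytotoxicity, read by MTT assay; on this read-out higher numbers stand for lower toxicity in this test and lower numbers for higher toxicity in this test: 250000 nM
- compound 2, `OC[C@@H]1[C@@H](O)[C@H](O)[C@@H](O)CN1CCCCCCOc1ccc(C(F)(F)F)cc1` — this assay: a limit, > 500000 nM

Going by the values given here, compound 1 is the only compound with a number in this assay; compound 2 gives only a limit and no number, and the limit of > 500000 nM in this assay, at which 1 of the 2 values shown sits, marks where that limit sits. Nothing can be said about the order of the two.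

Compound 3, `CCC1CCCCC1OCCCCCCN1C[C@H](O)[C@@H](O)[C@H](O)[C@H]1CO`, is not yet measured. It differs from compound 1 at one place: a group of 8 heavy atoms (8 carbon; one six-membered non-aromatic ring of carbon only) in place of a group of 9 heavy atoms (9 carbon; one six-membered non-aromatic ring of carbon only), on an oxygen on a saturated carbon. The change keeps a six-membered non-aromatic ring of carbon only on the same oxygen and removes one carbon, so the two compounds are closely related in shape and size.

The step from compound 1 to compound 3 is expected to be a 1.2-fold higher number from compound 1 to compound 3 (0.08 log units; within the scatter), within the scatter or little beyond it, with no firm direction. Compound 3 is expected to give about 300000 nM in this assay, between 120000 nM and 700000 nM.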

Compound 3, half-maximal cytotoxic concentration: 450000 nM
The estimate for compound 3 lay 1.5-fold (0.18 log units) below the measured number; the measured number falls inside the stated range.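

In this assay, going by these compounds alone, the series now has a first readable step on an oxygen on a saturated carbon: a 1.8-fold higher number from compound 1 to compound 3 (0.26 log units; within the scatter). The 3,3,5-trimethylcyclohexyl group and the group of 8 carbon atoms that enters in its place, both holding a six-membered non-aromatic ring of carbon only, leave compound 1 and compound 3 within the usual scatter of each other, so this single pair shows that this swap is tolerated and gives no trend with size or substitution. No measured property shown bears on this step.

Still open, as far as these compounds go, is how this read-out responds when a hydroxyl, an amine or a carboxylic acid is carried on the carbon ring. From the compounds shown here alone, a cyclopentyl or cycloheptyl ring on the same oxygen, or a longer chain to the core, also remains untested in these data.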